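The source may hold more compounds than are shown below. What is called first, only, known or untested is meant among the compounds shown, and "the series" means these compounds.

Measured compounds:
- compound 1 `COc1cc(OC)c2c(=O)c(OCC(=O)N/N=C/c3sccc3C)c(-c3cc(OC)c(OC)c(OC)c3)oc2c1`: 10300 nM
- compound 2 `COc1cc(OC)c2c(=O)c(OCCCCN3CCCC3)c(-c3cc(OC)c(OC)c(OC)c3)oc2c1`: 26800 nM
- compound 3 `COc1cc(OC)c2c(=O)c(OCCCCN3CCN(C)CC3)c(-c3cc(OC)c(OC)c(OC)c3)oc2c1`: 6950 nM

All three share one core and differ only in the side chain on the oxygen of the pyranone ring. In a functional assay on SGC-7901 cells (Homo sapiens) for cytotoxicity, read by MTT assay, with a stated time of 38 h (on this read-out higher numbers stand for weaker inhibition and lower numbers for stronger inhibition), compound 3 gives the lowest of the three numbers, but the step of a 1.5-fold lower number from compound 1 to compound 3 (0.17 log units; within the scatter) is within the scatter, so the two cannot be ranked. Going by the values given here, only the step of a 3.9-fold lower number from compound 2 to compound 3 (0.59 log units; beyond the scatter) is beyond the scatter, as is a 2.6-fold higher number from compound 1 to compound 2 (0.42 log units; beyond the scatter).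

Compound 4 `COc1cc(OC)c2c(=O)c(OCC(=O)N/N=C/c3ccccn3)c(-c3cc(OC)c(OC)c(OC)c3)oc2c1` has not been measured. Relative to compound 3 the change is a group of 11 heavy atoms (7 carbon, 3 nitrogen, 1 oxygen; one six-membered aromatic ring with 1 hetero atom) in place of a group of 10 heavy atoms (8 carbon, 2 nitrogen; one six-membered non-aromatic ring with 2 hetero atoms), on a saturated chain carbon bound to an oxygen on an aromatic ring. The side chain that enters is of the same kind as that of compound 1: a carbonyl-bearing hydrazone linker ending in an aromatic ring, with a six-membered ring carrying one nitrogen in place of a five-membered ring carrying one sulfur. The step that bears on this is a 1.5-fold lower number from compound 1 to compound 3 (0.17 log units; within the scatter), which is within the scatter, so a change from the chain of compound 3 to a hydrazone chain of this type has not moved the number meaningfully. Among the compounds with values here, no measured pair separates the two aromatic rings themselves. The expectation for compound 4 is therefore a number close to that of compound 1, a step of a 1.4-fold higher number from compound 3 to compound 4 (0.16 log units; within the scatter) that stays within the scatter. Compound 4 is estimated at 10000 nM, with a range of 4000 nM to 25000 nM.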

Compound 4, half-maximal inhibitory concentration: 16200 nM
For compound 4 the middle estimate is 1.6-fold (0.21 log units) below the measured one; measured number inside the range.
By their numbers in this assay, from the lowest: compounds 3, 1, 4 and 2 (each within the scatter of the next, the first and the last beyond it).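

In this assay, going by these compounds alone, the two aromatic rings on the hydrazone chain are compared directly for the first time (a 1.6-fold higher number from compound 1 to compound 4 (0.20 log units; within the scatter)), and pyridin-2-yl and 3-methylthiophen-2-yl cannot be ranked. The exchange of the 3-(4-methylpiperazin-1-yl)propyl chain for the pyridin-2-yl hydrazone chain clears the scatter (a 2.3-fold higher number from compound 3 to compound 4 (0.37 log units; beyond the scatter)), whereas the corresponding step with 3-methylthiophen-2-yl from compound 1 to compound 3 did not, so a hydrazone chain cannot be treated as equivalent to that chain in every case. Against the pyrrolidin-1-yl chain the picture also differs from that of compound 1, since this step stays within the scatter (a 1.7-fold lower number from compound 2 to compound 4 (0.22 log units; within the scatter)), and the two chains cannot be ranked here.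

A phenyl ring or a 4-methoxyphenyl ring on the hydrazone chain, or morpholin-4-yl or a carboxylic acid at the end of the saturated chain, would show whether any end group separates clearly from these four compounds. No supporting measurement is available to account for any of these steps.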